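Trimming a Methyl from the Ketone Side Chain

A few compounds are considered here, and "the series" means these few. Any claim that something is new, unique, unknown or untested is made for them only; others in the source may bear on it.

In an assay on HEK293 cells for positive allosteric modulation of metabotropic glutamate receptor 2 (Rattus norvegicus), read by thallium flux, with a stated time of 2.5 min (on this read-out higher numbers stand for larger maximal responses and lower numbers for smaller maximal responses), compound 2 `Cc1c(OCCCCOc2ccc(F)c(C(=O)O)c2)ccc(C(=O)CC(C)(C)C)c1O` gives 94.6%. Compound 3 `Cc1c(OCCCCOc2ccc(C(=O)CC(C)(C)C)c(O)c2C)cccc1C(=O)O` gives 95.8%, and the step of a number 1.2 percentage points higher from compound 2 to compound 3 (within the scatter) lies within the scatter, so these two cannot be told apart. Compound 1 `Cc1c(OCCCCOc2ccccc2C(=O)O)ccc(C(=O)CC2CCCC2)c1C` gives 67.1%, a gap from compound 2 that lies beyond the scatter. Compound 4 `Cc1c(OCCCCOc2ccc(F)c(C(=O)O)c2)ccc(C(=O)CC(C)C)c1O` is not yet measured. It differs from compound 2 by hydrogen in place of methyl on a saturated chain carbon bound to three saturated chain carbons. For the measured compounds named here, none of the measured steps touches this part of the molecule: the only single-point step, from compound 2 to compound 3, alters the aryl acid instead, and compound 1 differs in several places at once. With no guide, the step of a number 6.6 percentage points lower from compound 2 to compound 4 (within the scatter) is expected to be small. Compound 4 is therefore estimated at 88%, between 68% and 100%.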

Compound 4, largest response reached (reported as percent of maximum), in percent of the reference or control that the assay uses: 84.5%
The estimate for compound 4 lay 3.5 percentage points above the measured number, within the range that was stated.
By their numbers in this assay, from the lowest: compound 1; then compound 4; then compounds 2 and 3 (each within the scatter of the next).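

Trimming neopentylcarbonyl to isobutylcarbonyl gives a number 10.1 percentage points lower from compound 2 to compound 4 (beyond the scatter) in this assay, the first single-place change on this side chain. Removing this one methyl therefore has a modest but readable effect on the maximal response, whereas the earlier step, a number 1.2 percentage points higher from compound 2 to compound 3 (within the scatter), changed the aryl acid instead. Nothing available explains this drop.

From the compounds shown here alone, it remains open how an ethyl or trifluoromethyl group in place of this methyl would fare at the same carbon. Also open, going by these compounds, is whether the same trimming would lower the response with the aryl acid of compound 3.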